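The source may report more compounds than this note shows. Statements on the series, on what has been measured and on what is new or still open speak of the compounds shown alone.

Working notes on the series. Of the compounds shown here, three have been measured in an assay on HEK293 cells for positive allosteric modulation of metabotropic glutamate receptor 2 (Rattus norvegicus), read by thallium flux, with a stated time of 2.5 min; on this read-out lower numbers stand for smaller maximal responses and higher numbers for larger maximal responses. Compound 1 `COc1cc(C(=O)O)ccc1OCCCCOc1ccc(C(=O)C(C)C)c(O)c1C` gives 73.1%. Compound 2 `Cc1c(OCCCCOc2ccc(C(=O)O)cc2)ccc(C(=O)CC2CCCC2)c1O` gives 82.6%. Compound 3 `Cc1cc(C(=O)O)ccc1OCCCCOc1ccc(C(=O)CC(C)C)c(O)c1C` gives 83.9%. On these numbers compound 2 stands second highest of the three; its nearest neighbour is compound 3, whose number lies within the scatter of it, and the furthest is compound 1, whose number likewise lies within the scatter. All three values thus sit within the scatter of one another, and no order among them can be read from this read-out. Within the data shown here, no two measured compounds differ in a single place, so no measured step is available.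

Compound 4 `COC(=O)c1ccc(OCCCCOc2ccc(C(=O)CC3CCCC3)c(O)c2C)cc1` has not yet been measured. It differs from compound 2 in one place: methyl in place of hydrogen on an oxygen next to a carbonyl group, which at one bond further out reads carboxy to methoxycarbonyl, or 4-carboxyphenyl to 4-(methoxycarbonyl)phenyl.

Among the measured compounds shown here, with no measured step to lean on, the expectation rests on the cluster of three values and on the smallness of the change. The step is expected to be small, a number 3.6 percentage points lower from compound 2 to compound 4 (within the scatter), and none beyond the scatter in this assay in either direction. Compound 4 is therefore expected to give 79%, in a range from 62% to 95%.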

Compound 4, largest response reached (reported as percent of maximum), in percent of the reference or control that the assay uses: 12.2%
For compound 4 the middle estimate is 66.8 percentage points above the measured one; the whole stated range lies above it.
By their numbers in this assay, from the lowest: compound 4; then compounds 1, 2 and 3 (each within the scatter of the next, the first and the last beyond it).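

The step of a number 70.4 percentage points lower from compound 2 to compound 4 (beyond the scatter) shows that in this assay this position does not tolerate every small change: methyl in place of hydrogen on an oxygen next to a carbonyl group, reading carboxy to methoxycarbonyl, is enough to remove most of the response. Compounds 1, 2 and 3 all carry the carboxy group, so they could not show this sensitivity, whereas this single pair, with the rest of the structure held constant, ties the large step to 4-carboxyphenyl becoming 4-(methoxycarbonyl)phenyl. No measurement at hand explains the size of this step.

Going by these compounds, the change is seen on the core of compound 2 alone, so whether the same step would be as large with the substituted acid rings and shorter ketone side chains of compound 1 and compound 3 remains open. Also open, on these data alone, is what a primary amide, a tetrazole or an ethyl ester in place of the carboxy group would give, and whether any such group would keep the response of compound 2 or fall as far as compound 4.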